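Benzyl in place of cyclopentyl: a small expected step

The compounds below may be only part of what the source reports. "The series", "measured", "known", "first", "only" and "open" are said of these compounds alone.

Measured in a functional assay on MCF7 cells (Homo sapiens) for inhibition, read by sulforhodamine B assay, with a stated time of 48 h (a lower number here means a stronger inhibitor of growth, a higher number a weaker inhibitor of growth), so far
- Compound 1 `c1cc(OC2CCCCC2)ccc1NC1=NCCO1` gives 19100 nM
- Compound 2 `c1ccc(Oc2ccc(NC3=NCCO3)cc2)cc1` gives 3500 nM
- Compound 3 `O=C(CCl)NC(=O)Nc1cccc(OC2CCCC2)c1` gives 6200 nM

Compound 3 lies within the scatter of compound 2 and has a clearly lower number than compound 1. Compound 4 `O=C(CCl)NC(=O)Nc1cccc(OCc2ccccc2)c1` differs from compound 3 in one place benzyl in place of cyclopentyl on an oxygen on an aromatic ring with benzyl in place of cyclopentyl on an oxygen on an aromatic ring. For the measured compounds named here, one measured step bears on this, a 5.5-fold lower number from compound 1 to compound 2 (0.74 log units; beyond the scatter) for phenyl in place of cyclohexyl at that same kind of place. That step is modest and sits on another core, and phenyl is not benzyl, so it is only a loose guide. In this assay a small move toward a lower number is expected, perhaps no larger than the scatter. The estimated step is a 1.6-fold lower number from compound 3 to compound 4 (0.21 log units; within the scatter) as a best guess. Compound 4 is expected at 3800 nM within an estimated range of 1400 nM to 10000 nM on present evidence.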

Compound 4, concentration for 50% growth inhibition: 6200 nM
The estimate for compound 4 lay 1.6-fold (0.21 log units) below the measured number; the measured number falls inside the stated range.
By their numbers in this assay, from the lowest: compounds 2, 3 and 4 (each within the scatter of the next); then compound 1.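

In this assay, benzyl in place of cyclopentyl on an oxygen on an aromatic ring gives no change at the digits printed from compound 3 to compound 4 (within the scatter) on this core. Here, exchanging a non-aromatic carbon ring for one carrying an aromatic ring leaves the number within the scatter, unlike the phenyl for cyclohexyl exchange on the core of compound 1, which gave a 5.5-fold lower number from compound 1 to compound 2 (0.74 log units; beyond the scatter). No measured evidence here accounts for this result. From the compounds shown here alone, whether a longer chain such as phenylethyl, or an amine, on this oxygen would move the number remains open. So does how benzyl would behave on the core of compound 1.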